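The compounds below may be only part of what the source reports. "The series", "measured", "known", "first", "only" and "open" are said of these compounds alone.

Compound 1 `CC1=C(/C=C/C(=O)/C=C/c2ccc(Cl)cc2)C(C)(C)CCC1` and compound 2 `CC1=C(/C=C/C(=O)/C=C/c2ccccc2[N+](=O)[O-])C(C)(C)CCC1` share one core and differ only in the group carried on the aromatic ring. In a functional assay on PC-3 cells (Homo sapiens) for cytotoxicity, read by sulforhodamine B assay, with a stated time of 48 h (on this read-out higher numbers stand for weaker inhibition and lower numbers for stronger inhibition), compound 1 gives 9500 nM, and compound 2 gives 9500 nM, so compound 2 stands level with compound 1, within the scatter. Compound 3 `CC1=C(/C=C/C(=O)/C=C/c2ccccc2F)C(C)(C)CCC1` keeps the core of compound 2 and carries fluoro in place of nitro on an aromatic carbon. Among the measured compounds shown here, no measured pair shows this exchange. Because compound 1 at 9500 nM and compound 2 at 9500 nM give the same number, the expected step of a 1.1-fold lower number from compound 2 to compound 3 (0.02 log units; within the scatter) is none beyond the scatter. Compound 3 is therefore estimated at 9000 nM, between 4000 nM and 20000 nM.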

Compound 3, half-maximal inhibitory concentration: 3400 nM
Estimate against measurement, compound 3: 2.6-fold (0.42 log units) above; measured number below the stated range.
By their numbers in this assay, from the lowest: compound 3; then compounds 1 and 2 (each within the scatter of the next).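

In this assay the group on the aromatic ring can shift the number after all, which compound 1 and compound 2 alone, level with each other, did not show. Fluoro in place of nitro, ortho to a large group, gives a 2.8-fold lower number from compound 2 to compound 3 (0.45 log units; beyond the scatter) and stands beyond the scatter. Set against the other earlier compound, 2-fluorophenyl in place of 4-chlorophenyl gives a 2.8-fold lower number from compound 1 to compound 3 (0.45 log units; beyond the scatter) and also lies beyond the scatter. Nothing shown gives a reason for these steps. As far as these compounds go, whether an amine or a carboxylic acid on the same aromatic carbon would lower the number as well remains open.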